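Methyl to 4-Nitrophenyl on the Amine Arm

This account rests on a few compounds, and the source may have more. Where it says the series, first, only, none or still open, it means among the compounds named here.

Of the compounds shown here, three built on one shared core have been measured in a functional assay on A-431 cells (Homo sapiens) for inhibition, read by sulforhodamine B assay, with a stated time of 72 h; on this read-out higher numbers stand for weaker inhibition and lower numbers for stronger inhibition. Compound 1 `Cc1cc(=O)c2ccc(O)c(CN(Cc3ccccc3)Cc3ccccc3)c2o1` gives 19.5 ug/mL. Compound 2 `COc1ccc(CN(Cc2ccccc2)Cc2c(O)ccc3c(=O)cc(C)oc23)cc1` gives 44.7 ug/mL, and the change between them, methoxy in place of hydrogen on an aromatic carbon, was a 2.3-fold higher number from compound 1 to compound 2 (0.36 log units; beyond the scatter). Compound 3 `CCN(Cc1ccc(OC)cc1)Cc1c(O)ccc2c(=O)cc(C)oc12` gives 42 ug/mL; the step of a 1.1-fold lower number from compound 2 to compound 3 (0.03 log units; within the scatter) replaced phenyl with methyl on a saturated chain carbon bound to an amine nitrogen. Among the three numbers compound 3 stands second highest, close to compound 2 and clearly above compound 1.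

Compound 4 `COc1ccc(CN(Cc2ccc([N+](=O)[O-])cc2)Cc2c(O)ccc3c(=O)cc(C)oc23)cc1` has not yet been measured. It differs from compound 3 by 4-nitrophenyl in place of methyl on a saturated chain carbon bound to an amine nitrogen. The earlier step of a 1.1-fold lower number from compound 2 to compound 3 (0.03 log units; within the scatter) shows that phenyl and methyl at this place gave numbers within the scatter, so the return to an aromatic ring on its own should change little. Among the measured compounds shown here, no measured compound speaks to the nitro group itself; the only added ring substituent seen, the methoxy of a 2.3-fold higher number from compound 1 to compound 2 (0.36 log units; beyond the scatter), gave a modest rise. A step of about a 1.1-fold higher number from compound 3 to compound 4 (0.06 log units; within the scatter) is therefore expected. For compound 4 the estimate is 48 ug/mL, with a range from 22 ug/mL to 105 ug/mL.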

Compound 4, half-maximal inhibitory concentration: > 100 ug/mL
Compound 4 ended at the assay's limit (the forecaster's own chance of this, stated with the estimate: 5%); middle value at least 2.0-fold (0.31 log units) from the limit.
By their numbers in this assay, from the lowest: compound 1; then compounds 3 and 2 (each within the scatter of the next). At a limit, above all of these: compound 4.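

In this assay the reading of compound 4 is a limit of the assay and not a number: the limit of > 100 ug/mL in this assay, at which 1 of the 4 values shown sits. Phenyl and methyl on a saturated chain carbon bound to an amine nitrogen had given numbers within the scatter of each other, yet 4-nitrophenyl at this place gives an at least 2.3-fold higher number from compound 3 to compound 4 (0.37 log units; beyond the scatter), so what stands here can matter to inhibition. With the aromatic ring held constant, nitro in place of hydrogen gives an at least 2.2-fold higher number from compound 2 to compound 4 (0.34 log units; beyond the scatter), which ties the change to the nitro group and not to the return of a ring.

From the compounds shown here alone, how far compound 4 lies past the limit stays open, so the true size of both steps is unknown. Going by these compounds, whether an amine or a carboxylic acid in place of the nitro group would also weaken inhibition also stays open.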